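The source may hold more compounds than are shown below. What is called first, only, known or untested is meant among the compounds shown, and "the series" means these compounds.

In a functional assay (aorta) for inhibition, with Rattus norvegicus as the target (a lower number here means a stronger inhibitor, a higher number a weaker inhibitor), compound 1 (`Cc1nsc(-c2ccc(N3CCN(c4cccc(C(F)(F)F)c4)CC3)nc2)n1`) gives 5 nM. Compound 2 (`Cc1nsc(-c2ccnc(N3CCN(c4cccc(C(F)(F)F)c4)CC3)n2)n1`) is reported only as a limit, > 100 nM. Compound 3 (`FC(F)(F)c1cccc(N2CCN(c3ccc(-c4ncns4)nn3)CC2)c1`) gives 70 nM, the higher of the two actual numbers and beyond the scatter from compound 1. Compound 4 (`Cc1nsc(-c2ccc(N3CCN(c4cccc(C(F)(F)F)c4)CC3)nn2)n1`) differs from compound 3 by methyl in place of hydrogen on an aromatic carbon, which gives a 3-methyl-1,2,4-thiadiazol-5-yl group. Compound 1, at 5 nM, carries this group, although compound 2 carries it too. A moderate move towards stronger inhibition, beyond the scatter, is therefore expected, with an estimated 3.9-fold lower number from compound 3 to compound 4 (0.59 log units; beyond the scatter). Compound 4 is estimated at 18 nM, with an expected range of 4 nM to 80 nM.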

Compound 4, half-maximal inhibitory concentration: 0.3 nM
Beside the measured number, compound 4's estimate is 60-fold (1.78 log units) above it; measured number below the stated range.
By their numbers in this assay, from the lowest: compound 4; then compound 1; then compound 3. At a limit, above all of these: compound 2.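

In this assay, methyl in place of hydrogen on this aromatic carbon, between two ring nitrogen atoms, gives a 230-fold lower number from compound 3 to compound 4 (2.37 log units; beyond the scatter), a large step. Within the data shown here, it is the first direct reading of this change, as the earlier compounds included no pair differing in one place. Compound 2 also carries the 3-methyl-1,2,4-thiadiazol-5-yl group, yet it is reported only as a limit: the limit of > 100 nM in this assay, at which 1 of the 4 values shown sits.

On these data alone, it remains open whether an ethyl group, a methoxy group or a chlorine atom at this carbon would serve as well as methyl. As far as these compounds go, it also remains open whether the same change would give a similar step on the core of compound 1.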